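From 3-hydroxypyrrolidin-1-yl to 4-hydroxypiperidin-1-yl: a solubility estimate

The source may report more compounds than this note shows. Statements on the series, on what has been measured and on what is new or still open speak of the compounds shown alone.

Of the compounds shown here, three have so far been measured in a physicochemical assay for solubility, read by HPLC, using the shake flask method, with a stated time of 2 h, at pH 2; on this read-out higher numbers stand for higher solubility and lower numbers for lower solubility. Compound 1 `Nc1ncc(-c2ccc(C(=O)N3CCC(O)C3)cc2)nc1-c1ccc(C(F)(F)F)cc1` gives 129000 nM, compound 2 `Nc1ccc(-c2nc(-c3ccc(S(=O)(=O)C4CC4)cc3)cnc2N)cn1` gives 212000 nM and compound 3 `N#Cc1ccc(-c2cnc(N)c(-c3ccc(N)nc3)n2)cc1` gives 208000 nM. These three numbers all lie within the usual scatter of repeated measurements, so compound 1 cannot be told apart from the other two.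

Compound 4 `Nc1ncc(-c2ccc(C(=O)N3CCC(O)CC3)cc2)nc1-c1ccc(C(F)(F)F)cc1` keeps the core of compound 1 and alters a single group: 4-hydroxypiperidin-1-yl in place of 3-hydroxypyrrolidin-1-yl on a carbonyl carbon. A five-membered non-aromatic ring gives way to a six-membered one, on a carbonyl carbon, and the group still carries no net charge.

Among the measured compounds shown here, only one measured step is available, a 1.0-fold lower number from compound 2 to compound 3 (0.01 log units; within the scatter), where cyano takes the place of cyclopropylsulfonyl on an aromatic carbon. For the measured compounds named here, that step involves other groups at another place, so it offers only loose guidance, and no measured pair shows this swap on a carbonyl carbon. Since that single step stayed within the scatter, and nothing else points either way, no clear direction is expected here. The expected size is a 1.1-fold lower number from compound 1 to compound 4 (0.03 log units; within the scatter), which would also lie within the scatter. For compound 4 the estimate is 120000 nM, with an expected range from 55000 nM to 250000 nM.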

Compound 4, solubility: 119000 nM
Compound 4: the middle estimate sits 1.0-fold (0.00 log units) above what was measured, and the stated range covers the measured number.
By their numbers in this assay, from the lowest: compounds 4, 1, 3 and 2 (each within the scatter of the next).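

In this assay, putting 4-hydroxypiperidin-1-yl in place of 3-hydroxypyrrolidin-1-yl on a carbonyl carbon gives a 1.1-fold lower number from compound 1 to compound 4 (0.04 log units; within the scatter) and so lies within the scatter. Among the compounds shown here, this is the first measured change at this place, since the only earlier step was on an aromatic carbon, and it shows that, with the rest of compound 1 held fixed, the five-membered and six-membered rings cannot be told apart by this read-out. No available evidence bears on why these two compounds read alike.

This one pair keeps a hydroxyl group and no net charge on both sides, and it rests on a single core, so it cannot show whether the same would hold with other cores or with more different groups on the carbonyl carbon. From the compounds shown here alone, whether a piperazin-1-yl ring, a morpholin-4-yl ring, or a carboxylic acid in place of the hydroxyl group on the piperidine ring would also stay within the scatter remains open.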